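Replacing the methoxyphenyl ring in a sulfonamide series

The source may report more compounds than this note shows. Statements on the series, on what has been measured and on what is new or still open speak of the compounds shown alone.

Three compounds share a core in which a ketone chain links an aminochlorophenyl group to a piperidine, and the piperidine carries a sulfonamide. Compound 1 `COc1ccc(S(=O)(=O)N2CCC(CCC(=O)c3cc(Cl)c(N)cc3OC)CC2)cc1` has the sulfonamide nitrogen directly in the piperidine ring; in an assay on brain for displacement of a labelled ligand from 5-hydroxytryptamine receptor 4 (Cavia porcellus), with a stated time of 30 min, in the presence of a further agent that is not named here (a higher number here means a weaker inhibitor, a lower number a stronger inhibitor), compound 1 gives "not determined" (no result reported), so no result is reported for it. Compound 2 `COc1ccc(S(=O)(=O)NCCN2CCC(CCC(=O)c3cc(Cl)c(N)cc3OC)CC2)cc1` inserts a two-carbon linker between the piperidine nitrogen and the sulfonamide; in this assay compound 2 gives 12.3 nM, the higher of the two numbers reported. Going by the values given here, compound 3 `COc1cc(N)c(Cl)cc1C(=O)CCC1CCN(CCNS(=O)(=O)c2ccc(OC)c(N3CCN(C)CC3)c2)CC1` is the nearest entry: in this assay compound 3 gives 3.46 nM, and the only measured step is a 3.6-fold lower number from compound 2 to compound 3 (0.55 log units; beyond the scatter), a change on the same aromatic ring that compound 4 alters.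

Compound 4 `COc1cc(N)c(Cl)cc1C(=O)CCC1CCN(CCNS(=O)(=O)c2cc(Br)c(N)c(Br)c2)CC1` differs from compound 2 by 4-amino-3,5-dibromophenyl in place of 4-methoxyphenyl on a sulfonyl sulfur. Among the compounds with values here, no measured step swaps this ring itself, so the step to compound 3 offers only a loose guide that changes on this ring have been modest. The step of a 1.2-fold lower number from compound 2 to compound 4 (0.09 log units; within the scatter) is therefore expected to stay within or only just beyond the scatter, with no clear direction. Compound 4 is estimated at 10 nM, with a likely range from 3 nM to 40 nM.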

Compound 4, inhibition constant: 8.7 nM
Compound 4: middle estimate off by 1.1-fold (0.06 log units), on the high side, and the stated range covers the measured number.
By their numbers in this assay, from the lowest: compound 3; then compounds 4 and 2 (each within the scatter of the next).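

Exchanging the whole ring on the sulfonyl sulfur leaves the result in this assay essentially unchanged: a 1.4-fold lower number from compound 2 to compound 4 (0.15 log units; within the scatter). The earlier step, a 3.6-fold lower number from compound 2 to compound 3 (0.55 log units; beyond the scatter), kept the methoxy group and added 4-methylpiperazin-1-yl to the ring, whereas this one shows that 4-methoxyphenyl can give way entirely to 4-amino-3,5-dibromophenyl, which brings in an amine and two bromine atoms, with no measurable loss in this assay. The data shown hold nothing that bears on why the number stays within the scatter after so large a change in the group.

On these data alone, the amine and the two bromine atoms enter together and the methoxy group leaves in the same step, so the part each plays stays open, and a comparison with a simple 4-aminophenyl or 3,5-dibromophenyl group would be needed to separate them. Also open, as far as these compounds go, is how far this tolerance extends, for example whether a ring carrying a carboxylic acid in place of the amine would give a number close to those of compound 2 and compound 4.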